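Moving the Hydroxyl Group from Compound 2 to Compound 3

The compounds below may be only part of what the source reports. "The series", "measured", "known", "first", "only" and "open" are said of these compounds alone.

In a functional assay on MDA-MB-231 cells (Homo sapiens) for cytotoxicity, read by ELISA, with a stated time of 2 days (on this read-out lower numbers stand for stronger inhibition and higher numbers for weaker inhibition), compound 1 `Oc1cccc(-c2cc(-c3ccccc3)nc(-c3ccsc3)c2)c1` gives 19000 nM and compound 2 `Oc1cccc(-c2cc(-c3ccccc3)nc(-c3ccncc3)c2)c1` gives 12200 nM as its value. For the measured compounds named here, these two numbers lie within the scatter of each other, so compound 2 stands level with its only measured neighbour. Compound 3 `Oc1ccc(-c2cc(-c3ccccc3)nc(-c3ccncc3)c2)cc1` differs from compound 2 in one place: 4-hydroxyphenyl in place of 3-hydroxyphenyl on an aromatic carbon on the carbon opposite the ring nitrogen. Going by the values given here, only one measured step is available, a 1.6-fold lower number from compound 1 to compound 2 (0.19 log units; within the scatter) for pyridin-4-yl in place of thiophen-3-yl, and it bears on this change only loosely, since it concerns a different group. Among the compounds with values here, no measured pair tests a moved hydroxyl, so the data favour no direction. The expected change is a 1.0-fold lower number from compound 2 to compound 3 (0.01 log units; within the scatter) and thus none beyond the scatter. The estimated value for compound 3 is 12000 nM (expected range 4500 nM to 32000 nM).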

Compound 3, half-maximal inhibitory concentration: 2100 nM
The estimate for compound 3 lay 5.7-fold (0.76 log units) above the measured number; measured number below the stated range.
By their numbers in this assay, from the lowest: compound 3; then compounds 2 and 1 (each within the scatter of the next).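

Moving the hydroxyl group alone changes the result in this assay: 4-hydroxyphenyl in place of 3-hydroxyphenyl gives a 5.8-fold lower number from compound 2 to compound 3 (0.76 log units; beyond the scatter), even though the two groups are built from the same atoms. This shows that the read-out is sensitive to where the hydroxyl sits on the phenyl ring attached to the carbon opposite the ring nitrogen, something the earlier step could not show, as it concerned a different group and stayed within the scatter. Nothing available gives a reason for this difference. From the compounds shown here alone, it remains open whether a methoxy group or an amine in place of the hydroxyl of the 4-hydroxyphenyl group would keep the lower number. Going by these compounds, it is also open whether the same move would have a similar effect with thiophen-3-yl in place of pyridin-4-yl.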